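The source may hold more compounds than are shown below. What is called first, only, known or untested is meant among the compounds shown, and "the series" means these compounds.

Measured compounds:
compound 1 `CN(C)c1ccc(C(=O)N2CCC(NS(=O)(=O)c3cc(S(=O)(=O)c4ccccc4)ccc3C(F)(F)F)CC2)cc1` — 300 nM
compound 2 `CN(C)c1ccc(C(=O)N2CCC(NS(=O)(=O)c3cc(S(=O)(=O)c4ccccc4)ccc3C(F)(F)F)CC2)cn1` — 40 nM
compound 3 `O=C(O)c1cccc(S(=O)(=O)N2CCC(NS(=O)(=O)c3cc(S(=O)(=O)c4ccccc4)ccc3C(F)(F)F)CC2)c1` — 20 nM

All three share a core and differ only in the group attached to the ring amine nitrogen. In an assay on isolated protein for displacement of a labelled ligand from secreted frizzled-related protein 1 (Homo sapiens), read by fluorescence polarization, with a stated time of 30 min (on this read-out higher numbers stand for weaker inhibition and lower numbers for stronger inhibition), compound 3 gives the lowest of the three numbers. Its gap to compound 2 is small, a 2.0-fold lower number from compound 2 to compound 3 (0.30 log units; within the scatter), while its gap to compound 1 is clear, a 15-fold lower number from compound 1 to compound 3 (1.18 log units; beyond the scatter).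

Compound 4 `O=C(O)CCCC(=O)N1CCC(NS(=O)(=O)c2cc(S(=O)(=O)c3ccccc3)ccc2C(F)(F)F)CC1` is not yet measured. It carries the change ((3-carboxypropyl)carbonyl in place of (3-carboxyphenyl)sulfonyl on an amine nitrogen in a ring). The acid group is kept, but the aromatic ring and the sulfonyl link are gone, replaced by a short flexible chain on a carbonyl.

The two steps that bear on this are those landing on compound 3, since both alter the same position: a 15-fold lower number from compound 1 to compound 3 (1.18 log units; beyond the scatter) and a 2.0-fold lower number from compound 2 to compound 3 (0.30 log units; within the scatter). Both earlier groups at this position kept an aromatic ring; none of the three compounds shows what a ring-free chain does here. With the ring removed, a step toward a higher number in this assay is expected, a 7.5-fold higher number from compound 3 to compound 4 (0.88 log units; beyond the scatter), though the lack of a direct precedent makes the range wide. Compound 4 is therefore estimated at 150 nM, with a likely range from 40 nM to 600 nM.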

Compound 4, half-maximal inhibitory concentration: 500 nM
Beside the measured number, compound 4's estimate is 3.3-fold (0.52 log units) below it; the range from low to high includes it.
By their numbers in this assay, from the lowest: compounds 3 and 2 (each within the scatter of the next); then compounds 1 and 4 (each within the scatter of the next).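

Keeping a carboxylic acid at this ring nitrogen is not enough to hold the low number: in this assay, exchanging (3-carboxyphenyl)sulfonyl for (3-carboxypropyl)carbonyl gives a 25-fold higher number from compound 3 to compound 4 (1.40 log units; beyond the scatter), a large step. The flexible acid chain also compares poorly with one of the aromatic groups on the same carbonyl, with a 13-fold higher number from compound 2 to compound 4 (1.10 log units; beyond the scatter), while a 1.7-fold higher number from compound 1 to compound 4 (0.22 log units; within the scatter) stays within the scatter, so the chain and the 4-(dimethylamino)phenyl group cannot be told apart here. No measurement shown explains why these groups differ.

The change removes the aromatic ring and the sulfonyl link together, so the compounds shown leave open which loss accounts for the step; a 3-carboxybenzoyl group, which keeps the ring on a carbonyl, and a (3-carboxypropyl)sulfonyl group, which keeps the sulfonyl link on a chain, would separate the two. Also open, from the compounds shown here alone, is what the acid contributes on the flexible chain, which a longer chain ending in a carboxylic acid, or the same chain ending in an amine, would begin to address.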